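The source may report more compounds than this note shows. Statements on the series, on what has been measured and on what is new or still open speak of the compounds shown alone.

In a functional assay on THP-1 cells (Homo sapiens) for inhibition, read by ELISA, with stated times of 1 h and 18 h (a higher number here means a weaker inhibitor, a lower number a stronger inhibitor), compound 2 `NC(=O)[C@@H]1[C@H](Nc2nc(Nc3cccc(C(=O)N4CCCC4)c3)ncc2-c2ccoc2)[C@H]2C=C[C@@H]1C2` gives 40 nM. Compound 3 `NC(=O)[C@@H]1[C@H](Nc2nc(Nc3cccc(C(=O)N4CCCC4)c3)ncc2-c2ccncc2)[C@H]2C=C[C@@H]1C2` gives 320 nM and compound 1 `NC(=O)[C@@H]1[C@H](Nc2nc(Nc3ccc(C(=O)N4CCCC4)cc3)ncc2-c2cccnc2)[C@H]2C=C[C@@H]1C2` gives 230 nM, two numbers within the scatter of each other and both well above that of compound 2. Within the data shown here, compound 3 therefore stands at the high end of the numbers so far, level with compound 1.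

Compound 4 `N#Cc1ccc(-c2cnc(Nc3cccc(C(=O)N4CCCC4)c3)nc2N[C@H]2[C@@H](C(N)=O)[C@@H]3C=C[C@H]2C3)cc1` has not yet been measured. It departs from compound 3 by a single change, (4-cyanophenyl in place of pyridin-4-yl on an aromatic carbon), which amounts to 4-cyanophenyl in place of pyridin-4-yl on an aromatic carbon.

Among the measured compounds shown here, only one measured step touches this place, an 8.0-fold higher number from compound 2 to compound 3 (0.90 log units; beyond the scatter), a modest step beyond the scatter. It shows that the number in this assay can move when the group here is exchanged. For the measured compounds named here, it does not show which way a 4-cyanophenyl group would move it, since no measured compound carries one. Compound 1 differs from compound 3 in more than one place and offers no clean comparison. No step beyond the scatter is therefore expected, in either direction, but the range must stay wide enough for a step as large as the measured one. The estimate amounts to a 1.3-fold lower number from compound 3 to compound 4 (0.11 log units; within the scatter). For compound 4 the expected value is 250 nM, estimated to lie between 70 nM and 800 nM.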

Compound 4, half-maximal inhibitory concentration: 190 nM
Beside the measured number, compound 4's estimate is 1.3-fold (0.12 log units) above it; low and high end bracket the measured number.
By their numbers in this assay, from the lowest: compound 2; then compounds 4, 1 and 3 (each within the scatter of the next).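

In this assay, the exchange at this position gives a 1.7-fold lower number from compound 3 to compound 4 (0.23 log units; within the scatter), so the carbon-only ring of the 4-cyanophenyl group with its nitrile and the pyridin-4-yl ring with its ring nitrogen cannot be told apart here. The furan-3-yl group of compound 2 now stands apart from two six-membered aromatic groups rather than one: beside an 8.0-fold higher number from compound 2 to compound 3 (0.90 log units; beyond the scatter) there is now a 4.8-fold higher number from compound 2 to compound 4 (0.68 log units; beyond the scatter), and both steps lie beyond the scatter. Among these compounds, the gap to compound 2 therefore appears both with a ring nitrogen in the six-membered group and without one, which the single earlier step could not show.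

As far as these compounds go, it stays open whether a simple amine, a carboxylic acid, a methoxy-substituted phenyl ring or a thiophene ring at this position would give a number level with compound 2 or with compound 4. No measurement at hand explains why the furan-3-yl group stands apart from the two six-membered groups.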